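Aryl amide series: fluoro for methoxy, compound 1 to compound 4

A few compounds are considered here, and "the series" means these few. Any claim that something is new, unique, unknown or untested is made for them only; others in the source may bear on it.

Measured so far in an assay on HEK293 cells for activation of potassium channel subfamily T member 1 (Homo sapiens), read by thallium flux; on this read-out higher numbers stand for an effect only at larger amounts of compound and lower numbers for an effect already at smaller amounts:
compound 1 `COc1ccc(NC(=O)CN2CCN(S(=O)(=O)N3CCC(C)CC3)CC2)cc1` — > 10000 nM
compound 2 `CC1CCN(S(=O)(=O)N2CCN(CC(=O)Nc3ccccc3F)CC2)CC1` — > 10000 nM
compound 3 `COc1ccc(Cl)cc1NC(=O)CN1CCN(S(=O)(=O)N2CCN(C(=O)N3CCC(C)(C)CC3)CC2)CC1` — 9000 nM

Compound 1 stands at a limit of this assay: the reported value > 10000 nM is a limit and not a number. Compound 2 likewise reports only a limit, > 10000 nM. Within the data shown here, compound 3 is the one compound of the three with a number, 9000 nM, and it carries a different acyl piece on the shared core, so no single step connects it to compound 1.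

Compound 4 `CC1CCN(S(=O)(=O)N2CCN(CC(=O)Nc3ccc(F)cc3)CC2)CC1` has not been measured. Its difference from compound 1 is fluoro in place of methoxy on an aromatic carbon.

Among the measured compounds shown here, the only measured step that bears on it is a step that the two limits leave unreadable from compound 1 to compound 2, which cannot be read in size because both ends sit at the limit of > 10000 nM in this assay, at which 2 of the 3 values shown sit. No readable change on the aryl amide is therefore available, and the two limits give no direction.

For compound 4 a step that the limit leaves unreadable from compound 1 to compound 4 is estimated, that is, no step beyond the scatter. Compound 4 is expected at about 15000 nM, within 5000 nM to 60000 nM, most likely again reported as a limit.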

Compound 4, half-maximal effective concentration: > 10000 nM
Compound 4: a limit, no number; the forecaster's own chance of this, stated with the estimate: 80%; the middle value does not contradict the limit.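

Among these compounds, no step among compound 1, compound 2 and compound 4 can be read in this assay, because all three report only a limit: the limit of > 10000 nM in this assay, at which 3 of the 4 values shown sit.

Open remains whether fluoro in place of methoxy, or 4-fluorophenyl in place of 2-fluorophenyl, changes the read-out at all, and in which direction.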